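This account rests on a few compounds, and the source may have more. Where it says the series, first, only, none or still open, it means among the compounds named here.

Measured in an ADME assay on CEM-SS cells (Homo sapiens) for cytotoxicity, read by XTT assay, with a stated time of 6 days; a lower number here means that less compound is tolerated, a higher number that more compound is tolerated:
Compound 1 `CCCC(=O)OCSc1ccccc1C(=O)NCCCCC(N)=O` gives 51.7 uM.
Compound 2 `CCCC(=O)OCSc1ccccc1C(=O)N[C@@H]1CCC[C@H]1C(N)=O` gives 43.7 uM.
Compound 3 `CCCC(=O)OCSc1ccccc1C(=O)OCC(N)=O` gives 82.1 uM.

Compound 1 stands second highest of these three numbers; its nearest neighbour is compound 2, a 1.2-fold lower number from compound 1 to compound 2 (0.07 log units; within the scatter), and its furthest is compound 3, a 1.6-fold higher number from compound 1 to compound 3 (0.20 log units; within the scatter). Compound 4 `CCCC(=O)OCSc1ccccc1C(=O)NCC(=O)NCCN(C)C` differs from compound 1 in one place: (2-(dimethylamino)ethyl)carbamoyl in place of 3-carbamoylpropyl on a saturated chain carbon bound to an amide-type nitrogen. The two measured steps both reshape the chain that carries the terminal carboxamide in compound 1, and both stayed within the usual scatter. Taken together they suggest that changes in this region leave the tolerated concentration much as it is, so for this assay I expect no step beyond the scatter, a 1.0-fold lower number from compound 1 to compound 4 (0.01 log units; within the scatter). Compound 4 is therefore estimated at 50 uM, with a likely range from 25 uM to 100 uM.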

Compound 4, half-maximal toxic concentration: 76.9 uM
For compound 4 the middle estimate is 1.5-fold (0.19 log units) below the measured one; low and high end bracket the measured number.
By their numbers in this assay, from the lowest: compounds 2, 1, 4 and 3 (each within the scatter of the next).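

In this assay, putting (2-(dimethylamino)ethyl)carbamoyl, with 8 heavy atoms, in place of the 6-atom 3-carbamoylpropyl gives a 1.5-fold higher number from compound 1 to compound 4 (0.17 log units; within the scatter). For the compounds shown here, this place on the chain therefore accepts a group with more heavy atoms and a second nitrogen without a step beyond the scatter, which the earlier steps had not tested. Nothing given here explains this result. Going by these compounds, it remains open whether a carboxylic acid or a much longer chain at this place would also stay within the scatter.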